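The source may hold more compounds than are shown below. What is called first, only, known or untested is meant among the compounds shown, and "the series" means these compounds.

Of the compounds shown here, two have so far been measured in an assay on microsomes from intestine for inhibition of acyl-CoA:cholesterol acyltransferase (Oryctolagus cuniculus); on this read-out higher numbers stand for weaker inhibition and lower numbers for stronger inhibition. Compound 1 `CC(C)c1cccc(C(C)C)c1NC(=O)NC1CCCc2ccccc21` gives 850 nM. Compound 2 `CCc1cccc(CC)c1NC(=O)NCC1(c2ccccc2)CCCC1` gives 56 nM, the lowest of the two numbers, and its distance from compound 1 lies well beyond the usual scatter. Compound 3 `CCc1cccc(C(C)C)c1NC(=O)NCC1(c2ccccc2)CCCC1` differs from compound 2 in a single place: methyl in place of hydrogen on a saturated chain carbon bound to an aromatic carbon and a saturated chain carbon. Within the data shown here, no measured pair isolates this change, so its effect cannot be read from the data. The expected step is small, at most a slight move toward a lower number, and is estimated as a 1.2-fold lower number from compound 2 to compound 3 (0.09 log units; within the scatter). Compound 3 is therefore expected to give about 45 nM, within a range from 15 nM to 150 nM.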

Compound 3, half-maximal inhibitory concentration: 25 nM
The estimate for compound 3 lay 1.8-fold (0.26 log units) above the measured number, within the range that was stated.
By their numbers in this assay, from the lowest: compound 3; then compound 2; then compound 1.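

Going from ethyl to isopropyl, on a saturated chain carbon bound to an aromatic carbon and a saturated chain carbon, gives a 2.2-fold lower number from compound 2 to compound 3 (0.35 log units; beyond the scatter) in this assay and is the first single change that can be read here. One added methyl at this place is thus enough to shift the number beyond the scatter, and the shift is toward stronger inhibition. No available evidence bears on why this happens. As far as these compounds go, it remains open whether a propyl chain or a tert-butyl group at this place would lower the number further or raise it again.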